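The source may report more compounds than this note shows. Statements on the series, on what has been measured and on what is new or still open speak of the compounds shown alone.

Compound 1 `Cc1cc(NC(=O)c2cc([N+](=O)[O-])ccc2Cl)cc(-c2nc3ccccc3o2)c1O`: > 25000 nM
Compound 2 `O=C(Nc1ccc(O)c(-c2nc3ccccc3s2)c1)c1cc([N+](=O)[O-])ccc1Cl`: > 25000 nM

Neither entry is a number: each is a limit of an ADME assay on Raji cells (Homo sapiens) for cytotoxicity, with a stated time of 72 h; a lower number here means that less compound is needed, a higher number that more compound is needed for the effect. Compound 2 therefore has no exact value of its own, and it sits at the limit of > 25000 nM in this assay, at which 2 of the 2 values shown sit.

Compound 3 `Cc1cc(NC(=O)c2cc([N+](=O)[O-])ccc2Cl)cc(-c2nc3ccccc3s2)c1O` is compound 2 with a single change, methyl in place of hydrogen on an aromatic carbon, ortho to a hydroxy group and meta to a 1,3-benzothiazol-2-yl group: methyl in place of hydrogen on an aromatic carbon.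

Among the measured compounds shown here, no measured pair shows what such a change does in this assay, so no step beyond the usual scatter is expected, in either direction. This expectation starts from compound 2 at > 25000 nM, which is a limit. The expected change is a number no higher from compound 2 to compound 3 (the limit leaves the size open). A limit is again the likeliest report. For compound 3 the estimate is 25000 nM, with an expected range from 10000 nM to 50000 nM.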

Compound 3, half-maximal effective concentration: > 25000 nM
Compound 3: no number, only a limit; the forecaster's own chance of this, stated with the estimate: 80%; the middle value sits exactly at the limit.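

Compound 1, compound 2 and compound 3 all give only a limit in this assay, so the steps to compound 3 cannot be read: the limit of > 25000 nM in this assay, at which 3 of the 3 values shown sit. The compounds shown leave open what exact value each has, and whether methyl or 1,3-benzothiazol-2-yl changes it.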